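The source may report more compounds than this note shows. Statements on the series, on what has been measured and on what is new or still open speak of the compounds shown alone.

Within the data shown here, compound 1 `C=CC(=O)Nc1ccccc1Nc1ccc2c(C(=O)c3cc(OC)cc(OC)c3)c[nH]c2n1` is one of three compounds measured in a functional assay on Hep 3B2 cells (Homo sapiens) for antiproliferative activity, with a stated time of 72 h; on this read-out higher numbers stand for weaker inhibition and lower numbers for stronger inhibition; compound 1 gives 140 nM, the lowest number of the three. Compound 2 `C=CC(=O)Nc1cccc(C)c1Nc1ccc2c(C(=O)c3cc(OC)cc(OC)c3)c[nH]c2n1` gives 438 nM and compound 3 `C=CC(=O)NC1CCCCC1Nc1ccc2c(C(=O)c3cc(OC)cc(OC)c3)c[nH]c2n1` gives 258 nM. The step of a 3.1-fold higher number from compound 1 to compound 2 (0.50 log units; beyond the scatter) shows a modest weakening, while the step of a 1.8-fold higher number from compound 1 to compound 3 (0.27 log units; within the scatter) stays within the scatter. Compound 4 `C=CS(=O)(=O)Nc1ccccc1Nc1ccc2c(C(=O)c3cc(OC)cc(OC)c3)c[nH]c2n1` has not yet been measured. It differs from compound 1 by vinylsulfonyl in place of vinylcarbonyl on a nitrogen on an aromatic ring. Neither measured step changes this group, so no direct guide exists; both only show that other changes on the shared core leave potency near that of compound 1 or weaken it modestly. A modest weakening is therefore expected, a 2.3-fold higher number from compound 1 to compound 4 (0.36 log units; beyond the scatter). Compound 4 is estimated at 320 nM, within 100 nM to 1000 nM.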

Compound 4, half-maximal inhibitory concentration: 1030 nM
For compound 4 the middle estimate is 3.2-fold (0.51 log units) below the measured one, outside the stated range (above it).
By their numbers in this assay, from the lowest: compounds 1, 3 and 2 (each within the scatter of the next, the first and the last beyond it); then compound 4.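

In this assay, vinylsulfonyl in place of vinylcarbonyl on the nitrogen gives a 7.4-fold higher number from compound 1 to compound 4 (0.87 log units; beyond the scatter). The earlier steps shown here left this group untouched; this one shows that potency depends on what the nitrogen carries, and that the sulfonyl version of the group does not hold the level of compound 1. Nothing available accounts for this loss. The compounds shown leave open how an acetyl or a propanoyl group on this nitrogen would compare. They also leave open whether a longer chain such as butenoyl would hold the potency of compound 1.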